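Sulfonamide nitrogen swap on the acetylated glycosyl triazole series

This account rests on a few compounds, and the source may have more. Where it says the series, first, only, none or still open, it means among the compounds named here.

Three compounds of this series have numbers in a functional assay on MDA-MB-231 cells (Homo sapiens) for antiproliferative activity, read by XTT assay, with a stated time of 48 h; on this read-out lower numbers stand for stronger inhibition and higher numbers for weaker inhibition. Compound 1 `COC(=O)C(C)(C)N(Cc1cn([C@@H]2O[C@H](COC(C)=O)[C@@H](OC(C)=O)[C@H]2OC(C)=O)nn1)S(C)(=O)=O` gives 240000 nM; compound 2 `CC(=O)OC[C@H]1O[C@@H](n2cc(CN(c3ccccc3)S(=O)(=O)c3ccccc3)nn2)[C@H](OC(C)=O)[C@@H]1OC(C)=O` gives 100000 nM; compound 3 `COc1cccc(N(Cc2cn([C@@H]3O[C@H](COC(C)=O)[C@@H](OC(C)=O)[C@H](OC(C)=O)[C@H]3OC(C)=O)nn2)S(C)(=O)=O)c1` gives 220000 nM. Compound 3 stands second highest of the three: its number sits within the scatter of compound 1 and beyond it only against compound 2, which has the lowest number.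

Compound 4 `COC(=O)C(C)(C)N(Cc1cn([C@@H]2O[C@H](COC(C)=O)[C@@H](OC(C)=O)[C@H](OC(C)=O)[C@H]2OC(C)=O)nn1)S(C)(=O)=O` differs from compound 3 in one place: 1-(methoxycarbonyl)-1-methylethyl in place of 3-methoxyphenyl on a sulfonamide nitrogen. Among the compounds with values here, no measured pair spans this exact change. Compound 1 carries the same 1-(methoxycarbonyl)-1-methylethyl on its sulfonamide nitrogen and lands close to compound 3, so no step beyond the scatter is expected in this assay. Compound 4 is therefore estimated at 240000 nM, range 110000 nM to 520000 nM, meaning an expected step of a 1.1-fold higher number from compound 3 to compound 4 (0.04 log units; within the scatter).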

Compound 4, half-maximal inhibitory concentration: 225000 nM
For compound 4 the middle estimate is 1.1-fold (0.03 log units) above the measured one, and the stated range covers the measured number.
By their numbers in this assay, from the lowest: compound 2; then compounds 3, 4 and 1 (each within the scatter of the next).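

In this assay, within the data shown here, the first one-place pair at this sulfonamide nitrogen gives a 1.0-fold higher number from compound 3 to compound 4 (0.01 log units; within the scatter) and so does not separate 1-(methoxycarbonyl)-1-methylethyl from 3-methoxyphenyl, even though the entering group has no ring. The earlier compounds shown here differed from one another in more than one place and could not show this. Nothing available explains the result.

As far as these compounds go, whether a carboxylic acid or a longer alkyl chain on this sulfonamide nitrogen would give a step beyond the scatter stays open.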